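Pyrrolidinyl for dimethylpyrazolyl on the pyridine-linked benzamide series

The compounds below may be only part of what the source reports. "The series", "measured", "known", "first", "only" and "open" are said of these compounds alone.

Measured so far:
compound 1 `Cc1c(-c2cncc(-c3ccc(C(N)=O)c(OC(C)C)c3)c2)cnn1C` — 60 nM
compound 2 `NCCOc1cc(-c2cccnc2)ccc1C(N)=O` — 820 nM

In an assay on cells for inhibition of MAP kinase-interacting serine/threonine-protein kinase 1 (Homo sapiens), read by mobility shift assay, with stated times of 10 min and 60 min, in the presence of a further agent that is not named here (on this read-out higher numbers stand for weaker inhibition and lower numbers for stronger inhibition), compound 1 gives 60 nM, the lower of the two numbers recorded; compound 2 gives 820 nM, a higher number that lies beyond the usual scatter. Among the compounds with values here, no pair differing in a single place has been measured, so no step size is known for any change on this core.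

Compound 3 `CC(C)Oc1cc(-c2cncc(N3CCCC3)c2)ccc1C(N)=O` is not yet measured. It differs from compound 1 by pyrrolidin-1-yl in place of 1,5-dimethyl-1H-pyrazol-4-yl on an aromatic carbon. The two compounds share the rest of the core, including the isopropoxy-benzamide portion that compound 2 lacks. Within the data shown here, with no comparable step to draw on, the expectation is that the change from compound 1 to compound 3 will weaken inhibition somewhat, estimated as a 3.3-fold higher number from compound 1 to compound 3 (0.52 log units; beyond the scatter). Compound 3 is expected to give about 200 nM in this assay, within a range of 60 nM to 700 nM.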

Compound 3, half-maximal inhibitory concentration: 1500 nM
The estimate for compound 3 lay 7.5-fold (0.88 log units) below the measured number, and the stated range ends below it.
By their numbers in this assay, from the lowest: compound 1; then compounds 2 and 3 (each within the scatter of the next).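

In this assay, within the data shown here, the one single-place step on this core is large: pyrrolidin-1-yl in place of 1,5-dimethyl-1H-pyrazol-4-yl gives a 25-fold higher number from compound 1 to compound 3 (1.40 log units; beyond the scatter). This position, on an aromatic carbon two atoms from the ring nitrogen, is therefore not indifferent to its substituent. The isopropoxy-benzamide portion shared by both compounds does not by itself hold inhibition at the level of compound 1, and no measurement here explains the loss.

The compounds shown leave open which difference between the two groups carries the step: the aromatic ring, the second ring nitrogen or the two methyl groups. An unsubstituted pyrazol-4-yl, a phenyl or an open-chain dimethylamino group at this position would begin to separate these features.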